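Hydrazone aryl swap: from chlorohydroxyphenyl to thiophenyl

This account rests on a few compounds, and the source may have more. Where it says the series, first, only, none or still open, it means among the compounds named here.

Measured so far:
- compound 1 `COc1ccc(/C=N/NC(=O)CSc2nnc(-c3ccncc3)o2)cc1` gives 19800 nM in a functional assay on BGC-823 cells (Homo sapiens) for cytotoxicity, read by MTT assay, with a stated time of 48 h; on this read-out higher numbers stand for weaker inhibition and lower numbers for stronger inhibition
- compound 2 `O=C(CSc1nnc(-c2ccncc2)o1)N/N=C/c1cccc(F)c1` gives 27500 nM in this assay
- compound 3 `O=C(CSc1nnc(-c2ccncc2)o1)N/N=C/c1cc(Cl)ccc1O` gives 5470 nM in this assay

Within this set compound 3 gives the lowest number: a 3.6-fold lower number from compound 1 to compound 3 (0.56 log units; beyond the scatter) and a 5.0-fold lower number from compound 2 to compound 3 (0.70 log units; beyond the scatter), both beyond the scatter, while a 1.4-fold higher number from compound 1 to compound 2 (0.14 log units; within the scatter) stays within it. Compound 3 is therefore the strongest inhibitor among the three.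

Compound 4 `O=C(CSc1nnc(-c2ccncc2)o1)N/N=C/c1cccs1` is not yet measured. Relative to compound 3 the change is thiophen-2-yl in place of 5-chloro-2-hydroxyphenyl on a carbon with a double bond to nitrogen. For the measured compounds named here, no measured step introduces a thiophen-2-yl, so none bears on this change directly. What the steps do show is that the two other aryl groups examined on this carbon give higher numbers than the 5-chloro-2-hydroxyphenyl of compound 3, by a modest amount each time. Leaving that group is therefore expected to raise the number again, by a modest step; the size is uncertain given the unmeasured group.

Compound 4 is expected to give 20000 nM in this assay, estimated between 7000 nM and 55000 nM. This estimate implies the step of a 3.7-fold higher number from compound 3 to compound 4 (0.56 log units; beyond the scatter).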

Compound 4, half-maximal inhibitory concentration: 26700 nM
Beside the measured number, compound 4's estimate is 1.3-fold (0.13 log units) below it, and the stated range covers the measured number.
By their numbers in this assay, from the lowest: compound 3; then compounds 1, 4 and 2 (each within the scatter of the next).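

In this assay, moving off the 5-chloro-2-hydroxyphenyl to a thiophen-2-yl on the carbon with a double bond to nitrogen gives a 4.9-fold higher number from compound 3 to compound 4 (0.69 log units; beyond the scatter), so a third group, and now a five-membered aromatic ring with a sulfur atom rather than a six-membered ring of carbon only, also reads well apart from compound 3. Against the other two groups the thiophen-2-yl shows no separation, with a 1.0-fold lower number from compound 2 to compound 4 (0.01 log units; within the scatter) and a 1.3-fold higher number from compound 1 to compound 4 (0.13 log units; within the scatter), so that compounds 1, 2 and 4 form one level within the scatter and compound 3 stands as the strongest inhibitor of the four, beyond the scatter from each of the others. Nothing available explains why the 5-chloro-2-hydroxyphenyl alone stands apart at this position.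

Still open, from the compounds shown here alone, is whether the lower number of compound 3 goes with the hydroxyl, with the chlorine or only with both together, which a hydroxyphenyl without chlorine and a chlorophenyl without hydroxyl would separate. Also open, going by these compounds, is how an aminophenyl or a carboxylic acid on the aryl ring at this carbon would read in this assay.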